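A Furan-2-yl Variant of Compound 2

The source may hold more compounds than are shown below. What is called first, only, known or untested is meant among the compounds shown, and "the series" means these compounds.

Compound 1 `COc1ccc(/C=N/NC(=S)NC(C)(C)[C@H]2CC=C(C)CC2)cc1`: < 40 nM
Compound 2 `CC1=CC[C@H](C(C)(C)NC(=S)N/N=C/c2ccc(F)cc2)CC1`: < 40 nM

In a functional assay on PC-3 cells (Homo sapiens) for inhibition, read by sulforhodamine B assay, with a stated time of 48 h (a higher number here means a weaker inhibitor of growth, a lower number a stronger inhibitor of growth), compound 1 gives < 40 nM, which is a limit of the assay and not a number. In this assay compound 2 gives < 40 nM, again a limit of the assay. Compound 2 therefore stands at the floor of what was reported, with no number attached to it. Among the measured compounds shown here, the only measured step, a step that the two limits leave unreadable from compound 1 to compound 2, cannot be sized because the limit of < 40 nM in this assay, at which 2 of the 2 values shown sit, holds both values.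

Compound 3 `CC1=CC[C@H](C(C)(C)NC(=S)N/N=C/c2ccco2)CC1` differs from compound 2 by furan-2-yl in place of 4-fluorophenyl on a carbon with a double bond to nitrogen. For the measured compounds named here, no measured step touches this kind of change, and the one step that exists is unreadable, so nothing in the data points in either direction. Compound 3 is expected to sit near compound 2, which means a step that the limit leaves unreadable from compound 2 to compound 3 is estimated in this assay, with no direction beyond the scatter. Compound 3 is estimated at 35 nM in this assay, within a range from 10 nM to 150 nM, and the assay may well report only a limit again.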

Compound 3, concentration for 50% growth inhibition: 13500 nM
Estimate against measurement, compound 3: 390-fold (2.59 log units) below; measured number outside the range, above it.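

Furan-2-yl in place of 4-fluorophenyl gives an at least 330-fold higher number from compound 2 to compound 3 (2.52 log units; beyond the scatter) in this assay, and furan-2-yl in place of 4-methoxyphenyl gives an at least 330-fold higher number from compound 1 to compound 3 (2.52 log units; beyond the scatter), so the carbon with a double bond to nitrogen is now shown to be a place where the attached group matters greatly. The step between compound 1 and compound 2 cannot be read, but among these three compounds, both groups with a six-membered aromatic ring stay at the limit, while the one five-membered aromatic ring does not. Both new steps give only the least possible size, because neither compound 1 nor compound 2 carries a number: the limit of < 40 nM in this assay, at which 2 of the 3 values shown sit.

The three compounds cannot separate the change in ring size from the oxygen in the ring or from the loss of the fluoro or methoxy group, as furan-2-yl differs from the other two groups in all of these at once. They also leave open how an unsubstituted phenyl, a thiophen-2-yl or a pyridin-4-yl group would behave at this place, and whether compound 1 and compound 2 differ at all.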